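The compounds below may be only part of what the source reports. "The series", "measured", "known", "first", "only" and "open" are said of these compounds alone.

Measured in a functional assay on the whole organism (strain Swiss Albino) for inhibition, with Mus musculus as the target, in the writhing test, with a stated time of 1 h, at a dose of 100 mg/kg by the oral route; a lower number here means less inhibition, a higher number more inhibition at the dose given (going by the name of the read-out):
compound 1, `COc1cc2c(cc1OC)C(CC(=O)O)CC2`: 44%
compound 2, `COc1cc2c(cc1OC)C(CC(=O)Nc1ccc(Cl)cc1)CC2`: 73.6%
compound 3, `COc1ccccc1NC(=O)CC1CCc2cc(OC)c(OC)cc21`: 24.5%

Compound 3 stands lowest of the three: in this assay compound 3 gives 24.5%, against compound 1 at 44% and compound 2 at 73.6%. Both gaps lie beyond the scatter.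

The next compound, compound 4, is `COc1cc2c(cc1OC)C(CC(=O)Nc1ccncc1)CC2`. It differs from compound 3 in one place: pyridin-4-yl in place of 2-methoxyphenyl on an amide-type nitrogen

Two measured steps give a sense of scale. The step of a number 29.6 percentage points higher from compound 1 to compound 2 (beyond the scatter) shows that converting the carboxylic acid into an arylamide raised inhibition modestly. The step of a number 49.1 percentage points lower from compound 2 to compound 3 (beyond the scatter) shows that the identity of the aryl group on the amide-type nitrogen matters a great deal, with a large drop. The change to compound 4 is of the same kind as the second step, a swap of the aryl group on the amide nitrogen, so a step beyond the scatter is expected, and since compound 3 sits at the bottom of the range, it is estimated to go upward. Compound 4 is expected to reach about 45%, within 20% to 70%, an expected step of a number 20.5 percentage points higher from compound 3 to compound 4 (beyond the scatter).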

Compound 4, a percentage reported as inhibition, in the whole organism at one dose (the size of the read-out at that dose, not a potency): 60.1%
Estimate against measurement, compound 4: 15.1 percentage points below, within the range that was stated.
By their numbers in this assay, from the lowest: compound 3; then compound 1; then compound 4; then compound 2.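

On the amide-type nitrogen, pyridin-4-yl in place of 2-methoxyphenyl brings a number 35.6 percentage points higher from compound 3 to compound 4 (beyond the scatter), so an aromatic ring with a hetero atom can carry much of the inhibition seen with these amides, though pyridin-4-yl in place of 4-chlorophenyl still costs a number 13.5 percentage points lower from compound 2 to compound 4 (beyond the scatter). Against the free acid, the pyridin-4-yl amide shows a number 16.1 percentage points higher from compound 1 to compound 4 (beyond the scatter), which makes it the second amide to stand above the acid, while compound 3, at 24.5%, goes against that pattern with compound 1 at 44%. Nothing measured here accounts for these differences.

The compounds shown leave open whether the low value of compound 3 follows from the methoxy group itself or from where it sits, which a 4-methoxyphenyl group on the same nitrogen could test. From the compounds shown here alone, whether the ring nitrogen's place matters also stays open, as pyridin-3-yl or pyridin-2-yl would show.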